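A few compounds are considered here, and "the series" means these few. Any claim that something is new, unique, unknown or untested is made for them only; others in the source may bear on it.

Of the compounds shown here, two have so far been measured in a functional assay on a cell-free system (plasma) for inhibition of thromboxane A2 receptor (Homo sapiens), read by turbidimetry; on this read-out lower numbers stand for stronger inhibition and higher numbers for weaker inhibition. Compound 1 `O=C(O)CC/C=C\C[C@H]1[C@H](F)CC[C@@H]1NS(=O)(=O)c1ccc(Cl)c(Cl)c1` gives 1700 nM in this assay. Compound 2 `Cc1ccc(S(=O)(=O)N[C@H]2CC[C@@H](F)[C@@H]2CCCCOCC(=O)O)cc1` gives 1800 nM in this assay. On these two numbers compound 2 sits at the higher one, yet the gap to compound 1 is within the usual scatter, so the two readings cannot be told apart. Compound 3 `Cc1ccc(S(=O)(=O)N[C@H]2CC[C@@H](F)[C@@H]2C/C=C\CCC(=O)O)cc1` has not yet been measured. It differs from compound 2 in one place: 4-carboxybut-1-en-1-yl in place of 3-(carboxymethoxy)propyl on a saturated chain carbon bound to a saturated ring carbon. Within the data shown here, the chain that enters is the one compound 1 carries on a different core, and with it compound 1 gives 1700 nM, so no large move is expected. In this assay the step from compound 2 to compound 3 is expected to be a 1.5-fold lower number from compound 2 to compound 3 (0.18 log units; within the scatter), at most a modest shift toward a lower number. Compound 3 is therefore expected to give about 1200 nM, with a likely range from 300 nM to 5000 nM.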

Compound 3, half-maximal inhibitory concentration: 1900 nM
Compound 3: the middle estimate sits 1.6-fold (0.20 log units) below what was measured; measured number inside the range.
By their numbers in this assay, from the lowest: compounds 1, 2 and 3 (each within the scatter of the next).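

Putting 4-carboxybut-1-en-1-yl in place of 3-(carboxymethoxy)propyl on a saturated chain carbon bound to a saturated ring carbon gives, in this assay, a 1.1-fold higher number from compound 2 to compound 3 (0.02 log units; within the scatter) and so the two chains cannot be told apart here, even though the entering chain has one more double bond and one fewer hydrogen-bond acceptor. The result also gives a one-place comparison at the sulfonyl sulfur, where 4-methylphenyl in place of 3,4-dichlorophenyl gives a 1.1-fold higher number from compound 1 to compound 3 (0.05 log units; within the scatter) and again the two readings cannot be told apart. Nothing measured here bears on this result.

From the compounds shown here alone, all three compounds carry a carboxylic acid on the chain, so it remains open whether a tetrazole or an amide in its place would shift the number beyond the scatter. Going by these compounds, a much shorter chain, or a methoxy group on the phenyl ring, is equally open.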